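This account rests on a few compounds, and the source may have more. Where it says the series, first, only, none or still open, it means among the compounds named here.

In a functional assay on A549 cells (Homo sapiens) for antiproliferative activity, read by MTT assay, with a stated time of 48 h (a higher number here means a weaker inhibitor, a lower number a stronger inhibitor), compound 1 `COc1ccc2nc(NC(c3cn(-c4ccccc4)nc3-c3ccc([N+](=O)[O-])cc3)c3c(O)ccc4ccccc34)sc2c1` gives 22500 nM and compound 2 `COc1ccc2nc(NC(c3cn(-c4ccccc4)nc3-c3cccc([N+](=O)[O-])c3)c3c(O)ccc4ccccc34)sc2c1` gives 52200 nM as the higher of the two numbers, which makes compound 2 the weaker inhibitor of this pair. Compound 3 `O=[N+]([O-])c1cccc(-c2nn(-c3ccccc3)cc2C(Nc2nc3ccc(Cl)cc3s2)c2c(O)ccc3ccccc23)c1` keeps the 3-nitrophenyl group of compound 2 and differs from it in one place (chloro in place of methoxy on an aromatic carbon): chloro in place of methoxy on an aromatic carbon, so that 6-methoxy-1,3-benzothiazol-2-yl becomes 6-chloro-1,3-benzothiazol-2-yl. Among the compounds with values here, no measured pair tests this swap. Within the data shown here, the only step available (a 2.3-fold higher number from compound 1 to compound 2 (0.37 log units; beyond the scatter)) is a modest one that concerns the nitrophenyl group and not this place, so it offers a rough sense of how far one small change can move the number but sets no direction. From the compounds shown here alone, on that thin evidence, no step beyond the scatter is expected in this assay and either direction remains open. The expected change is small (a 1.2-fold lower number from compound 2 to compound 3 (0.06 log units; within the scatter)) and remains uncertain. For compound 3 the estimated value is 45000 nM with 17000 nM to 110000 nM as its expected range.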

Compound 3, half-maximal inhibitory concentration: 42500 nM
Estimate against measurement, compound 3: 1.1-fold (0.02 log units) above, and the stated range covers the measured number.
By their numbers in this assay, from the lowest: compounds 1, 3 and 2 (each within the scatter of the next, the first and the last beyond it).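

The step from 6-methoxy-1,3-benzothiazol-2-yl to 6-chloro-1,3-benzothiazol-2-yl, with the 3-nitrophenyl group held in place, is a 1.2-fold lower number from compound 2 to compound 3 (0.09 log units; within the scatter), so compound 2 and compound 3 cannot be told apart in this assay. Within the data shown here, this is the first reading at this place, as the earlier pair differed only in the nitrophenyl group, and it shows that here a methoxy group with two heavy atoms and one hydrogen-bond acceptor can give way to a chloro group with one heavy atom and no acceptor without a change beyond the scatter. Nothing available offers an explanation for this result, and a single pair cannot show whether the place is generally tolerant.

Whether the swap stays this small alongside the 4-nitrophenyl group of compound 1 remains open, since the compounds shown include no chloro partner for it. Also open, from the compounds shown here alone, is how an amine, a carboxylic acid or a longer chain such as butoxy would behave at this same place. Methoxy and chloro are only two of the groups it could carry.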